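Adding a second chloro to a chlorinated purine core

The source may report more compounds than this note shows. Statements on the series, on what has been measured and on what is new or still open speak of the compounds shown alone.

Of the compounds shown here, three have been tested in a functional assay on MCF7 cells (Homo sapiens) for cytotoxicity, read by sulforhodamine B assay, with a stated time of 48 h; on this read-out lower numbers stand for stronger inhibition of growth and higher numbers for weaker inhibition of growth. Compound 1 `ClCc1ccccc1Cn1cnc2c(Cl)nc(Cl)nc21` gives 810 nM. Compound 2 `ClCc1ccccc1Cn1cnc2c(Cl)ncnc21` gives 11000 nM, and compound 3 `ClCc1ccccc1Cn1cnc2ncnc(Cl)c21` gives 3630 nM. Compounds 2 and 3 are built from the same atoms joined differently; the difference between the two cores is not broken down here. Moving from compound 2 to compound 1 involves one change, (chloro in place of hydrogen on an aromatic carbon), and this produced a 14-fold lower number from compound 2 to compound 1 (1.13 log units; beyond the scatter). Compound 4 `ClCc1ccccc1Cn1cnc2nc(Cl)nc(Cl)c21` has not yet been measured in this assay. It differs from compound 3 by chloro in place of hydrogen on an aromatic carbon, the same change placed the same way. Compound 4 is therefore expected to show a 12-fold lower number from compound 3 to compound 4 (1.08 log units; beyond the scatter), because the step of a 14-fold lower number from compound 2 to compound 1 (1.13 log units; beyond the scatter) was large in the same assay. The estimate for compound 4 is 300 nM, lying between 110 nM and 900 nM.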

Compound 4, concentration for 50% growth inhibition: 1040 nM
Estimate against measurement, compound 4: 3.5-fold (0.54 log units) below, and the stated range ends below it.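

In this assay, the added chloro again gives a lower number, a 3.5-fold lower number from compound 3 to compound 4 (0.54 log units; beyond the scatter), so the direction of the step carries over to the second core. The size of the step does not carry over, as the two cores give clearly different results: the same change on two cores in this assay, a 14-fold lower number (1.13 log units; beyond the scatter) from compound 2 to compound 1 and a 3.5-fold lower number (0.54 log units; beyond the scatter) from compound 3 to compound 4, 3.9-fold (0.59 log units) apart, beyond the scatter of two such steps. Within the data shown here, with only two cores, the change can be trusted here for its direction but not for its size, and these compounds do not show why the size differs.

Only hydrogen and chloro appear on the aromatic carbon between two ring nitrogen atoms. From the compounds shown here alone, how an amine or a methoxy group there would compare on either core remains open.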